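From compound 2 to compound 4: adding one chloro

This account rests on a few compounds, and the source may have more. Where it says the series, first, only, none or still open, it means among the compounds named here.

Compound 1 `O=C(Nc1ccc(Cl)c(Cl)c1)c1cc(F)ccc1O` gives 670 nM
Compound 2 `O=C(Nc1cccc(C(F)(F)F)c1)c1cc(F)ccc1O` gives 840 nM
Compound 3 `O=C(Nc1cccc(OC(F)(F)F)c1)c1cc(F)ccc1O` gives 700 nM

In a functional assay on Jurkat cells (Homo sapiens) for cytotoxicity, read by luminescence and CellTiter-Glo, with a stated time of 3 days (a higher number here means a weaker inhibitor, a lower number a stronger inhibitor), compound 2 stands at 840 nM, and the three measured compounds all lie within the scatter of one another. The next compound, compound 4 `O=C(Nc1ccc(Cl)c(C(F)(F)F)c1)c1cc(F)ccc1O`, differs from compound 2 by one change: chloro in place of hydrogen on an aromatic carbon. Going by the values given here, no measured step shows chloro in place of hydrogen directly. Among the compounds with values here, the only measured step, a 1.2-fold lower number from compound 2 to compound 3 (0.08 log units; within the scatter), puts trifluoromethoxy in place of trifluoromethyl and stays within the scatter. Compound 1 already carries a chloro para to a large group, and at 670 nM it cannot be told apart from compound 2. Across these three compounds, then, the exchanges seen have left the number essentially unmoved, although that evidence for a new chloro is indirect. The expected change in this assay is small, with at most a slight drift to a lower number, and the estimated step is a 1.4-fold lower number from compound 2 to compound 4 (0.15 log units; within the scatter). For compound 4 the estimated value is 600 nM, with an expected range of 300 nM to 1200 nM.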

Compound 4, half-maximal inhibitory concentration: 530 nM
Compound 4: the middle estimate sits 1.1-fold (0.05 log units) above what was measured, and the stated range covers the measured number.
By their numbers in this assay, from the lowest: compounds 4, 1, 3 and 2 (each within the scatter of the next).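

In this assay, going by these compounds alone, the step of a 1.6-fold lower number from compound 2 to compound 4 (0.20 log units; within the scatter) gives the first direct reading of chloro in place of hydrogen on this aromatic carbon, ortho to a trifluoromethyl group and para to a large group, and this carbon tolerates the added chloro without a shift beyond the scatter. With that chloro kept, the step of a 1.3-fold lower number from compound 1 to compound 4 (0.10 log units; within the scatter) shows that trifluoromethyl and chloro also cannot be told apart on the other substituted carbon of this ring. No measurement at hand explains why these exchanges leave the number so little changed.

The compounds shown leave open whether an amine, a carboxylic acid or a longer chain on this carbon would move the number beyond the scatter. They also leave open what replacing the hydroxy or fluoro groups of the shared core would do.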